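A few compounds are considered here, and "the series" means these few. Any claim that something is new, unique, unknown or untested is made for them only; others in the source may bear on it.

The measured compounds:

Compound 1, `CCc1cc(C(C)=O)c(O)cc1OCCCCCCCC(C)(C)C#N`, with 29% in an assay on isolated protein for binding affinity to leukotriene B4 receptor 1 (Homo sapiens), tested at 1 uM; a higher number here means more inhibition at the concentration tested (going by the name of the read-out), a lower number less inhibition.
Compound 2, `CCc1cc(C(C)=O)c(O)cc1OCCCCCCC(=O)Nc1nn[nH]n1`, with 83% in this assay.

Among these two numbers compound 1 stands lowest; its nearest neighbour is compound 2, and the single measured step, a number 54 percentage points higher from compound 1 to compound 2 (beyond the scatter), is large and beyond the scatter. Compound 3, `CCc1cc(C(C)=O)c(O)cc1OCCCCc1nnn[nH]1`, has not yet been measured. It differs from compound 1 as follows: 1H-tetrazol-5-yl in place of 4-cyano-4-methylpentyl on a saturated chain carbon, four bonds along the chain from an oxygen on an aromatic ring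

Going by the values given here, only the step from compound 1 to compound 2 bears on this change, since in both cases a nitrile-bearing chain end is given up and a tetrazole ring is brought in. That step was large and upward. In compound 3, however, the tetrazole sits directly on a shorter chain, without the carbamoyl link of compound 2, so the author expects an upward step, a number 31 percentage points higher from compound 1 to compound 3 (beyond the scatter), but with less certainty than the measured step alone would suggest. Compound 3 is therefore estimated at 60% in this assay, within a range of 35% to 85%.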

Compound 3, a percentage reported as inhibition, at one concentration (the size of the read-out at that concentration, not a potency): 19%
Beside the measured number, compound 3's estimate is 41 percentage points above it; measured number below the stated range.
By their numbers in this assay, from the lowest: compounds 3 and 1 (each within the scatter of the next); then compound 2.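

In this assay, putting 1H-tetrazol-5-yl in place of 4-cyano-4-methylpentyl on a saturated chain carbon, four bonds along the chain from an oxygen on an aromatic ring, gives a number 10 percentage points lower from compound 1 to compound 3 (within the scatter). The exchange at this position thus leaves the read-out within the scatter, and the large step seen earlier, a number 54 percentage points higher from compound 1 to compound 2 (beyond the scatter), does not carry over to this tetrazole-bearing compound, so a tetrazole ring on the chain is not enough on its own to give a step of that size. Nothing measured here bears on why the two exchanges end so differently.

Compound 2 and compound 3 differ in more than one place, in the carbamoyl link and in the chain, so the compounds shown cannot tell which of these goes with the high number of compound 2. Still open, going by these compounds, are a longer chain ending directly in 1H-tetrazol-5-yl, a chain of the length in compound 3 with the carbamoyl link restored, and a carboxylic acid at the chain end in place of the tetrazole ring.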